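The source may report more compounds than this note shows. Statements on the series, on what has been measured and on what is new or still open speak of the compounds shown alone.

Working notes on the series. Among the compounds with values here, the common core carries a urea-type side chain and a substituent on the aromatic ring; the three measured members are compound 1 `CN1CCC(c2ccc3c(c2)oc(=O)n3C(=O)NCCCCc2ccc(F)cc2)CC1`, compound 2 `CCCCCNC(=O)n1c(=O)oc2cc(-c3ccc(F)cc3)ccc21` and compound 3 `CCOCCNC(=O)n1c(=O)oc2cc(-c3ccc(F)cc3)ccc21`. In an assay on HEK293 cells for inhibition of acid ceramidase (Homo sapiens), read by fluorescence, with stated times of 10 min and 3 h (on this read-out lower numbers stand for stronger inhibition and higher numbers for weaker inhibition), compound 2 gives 60 nM, the lowest of the three numbers; compound 1 gives 94 nM, within the scatter of compound 2, and compound 3 gives 2300 nM, far above it. Within the data shown here, the only single-point step measured so far, a 38-fold higher number from compound 2 to compound 3 (1.58 log units; beyond the scatter), concerns the side chain, not the ring substituent.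

Compound 4 `CCCCCNC(=O)n1c(=O)oc2cc(C3CCN(C)CC3)ccc21` is the next candidate. Relative to compound 2 the change is 1-methylpiperidin-4-yl in place of 4-fluorophenyl on an aromatic carbon. Among the measured compounds shown here, no measured step covers this exchange on its own. Compound 1 carries the same 1-methylpiperidin-4-yl group but also a different side chain, so its value against compound 2 mixes two changes; all it shows is that a core bearing 1-methylpiperidin-4-yl can give a number close to that of compound 2. On that basis compound 4 is expected to show a 2.5-fold higher number from compound 2 to compound 4 (0.40 log units; beyond the scatter) in this assay, a shift not clearly beyond the scatter. The estimate for compound 4 is 150 nM, with a range from 40 nM to 600 nM.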

Compound 4, half-maximal inhibitory concentration in the acid ceramidase assay: 396 nM
Compound 4: the middle estimate sits 2.6-fold (0.42 log units) below what was measured; the measured number falls inside the stated range.
By their numbers in the acid ceramidase assay, from the lowest: compounds 2 and 1 (each within the scatter of the next); then compound 4; then compound 3.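

In the acid ceramidase assay the exchange of 4-fluorophenyl for 1-methylpiperidin-4-yl on this aromatic carbon, now read on its own, gives a 6.6-fold higher number from compound 2 to compound 4 (0.82 log units; beyond the scatter), and with 1-methylpiperidin-4-yl held fixed, methyl in place of 4-fluorophenyl on the side chain gives a 4.2-fold higher number from compound 1 to compound 4 (0.62 log units; beyond the scatter), so the closeness of compound 1 and compound 2 rests on two changes that pull in opposite directions in these compounds. In a physicochemical assay for solubility, read by HPLC, in phosphate buffer, measured as kinetic solubility, with a stated time of 1 h, at pH 7.4, tested at 250 uM (a higher number here means a more soluble compound, a lower number a less soluble compound), compound 2 gives < 1000 nM, which is a limit of the assay and not a number. In the physicochemical assay compound 4 gives 240000 nM. At this position, the exchange that weakens inhibition also goes with a clear gain in solubility: the measured solubility of compound 2, < 1000 nM, and of compound 4, 240000 nM, an at least 240-fold higher number (2.38 log units; beyond the scatter)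

Still open, as far as these compounds go, is which part of the exchange carries these two shifts, the non-aromatic ring or the nitrogen it holds, a question that a pyridin-4-yl or a morpholine group on the same carbon would bear on. Also open, from the compounds shown here alone, is how far the side chain of compound 1, with its 4-fluorophenyl group, retains the solubility seen for compound 4.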